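Swapping the Halogenated Ring for an Ethylphenyl Group

The source may hold more compounds than are shown below. What is called first, only, known or untested is meant among the compounds shown, and "the series" means these compounds.

Of the compounds shown here, three built on one shared core have been measured in a functional assay on MGC-803 cells (Homo sapiens) for antiproliferative activity, read by MTT assay, with a stated time of 48 h; on this read-out lower numbers stand for stronger inhibition and higher numbers for weaker inhibition. Compound 1 `O=C(Nc1cccc(CNc2nccnc2Cl)c1)Nc1ccc(Cl)cc1Br` gives 7480 nM in this assay. Compound 2 `O=C(Nc1cccc(CNc2nccnc2Cl)c1)Nc1cccc(C(F)(F)F)c1` gives 7290 nM, and compound 3 `O=C(Nc1ccc(C(F)(F)F)cc1)Nc1cccc(CNc2nccnc2Cl)c1` gives 6910 nM. Compound 1 carries the highest of the three numbers, yet its gaps to compound 2 and to compound 3 both lie within the usual scatter of repeated measurements, so the three compounds cannot be separated on these values.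

Compound 4 `CCc1ccccc1NC(=O)Nc1cccc(CNc2nccnc2Cl)c1` has not yet been measured. It differs from compound 1 in one place: 2-ethylphenyl in place of 2-bromo-4-chlorophenyl on an amide-type nitrogen. Because compound 1 gives 7480 nM, compound 2 gives 7290 nM and compound 3 gives 6910 nM with three different aryl groups on that amide-type nitrogen, a fourth aryl group is expected to land in the same region, with no step beyond the scatter in either direction. The expected step is a 1.1-fold higher number from compound 1 to compound 4 (0.03 log units; within the scatter). Compound 4 is therefore estimated at 8000 nM, within a range from 4000 nM to 16000 nM.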

Compound 4, half-maximal inhibitory concentration: 9370 nM
The estimate for compound 4 lay 1.2-fold (0.07 log units) below the measured number; low and high end bracket the measured number.
By their numbers in this assay, from the lowest: compounds 3, 2, 1 and 4 (each within the scatter of the next).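

The change from 2-bromo-4-chlorophenyl to 2-ethylphenyl on the amide-type nitrogen gives a 1.3-fold higher number from compound 1 to compound 4 (0.10 log units; within the scatter), so in this assay it cannot be told apart from no change at all. The aryl groups of compounds 1, 2 and 3 all carry halogen atoms, whereas the 2-ethylphenyl group of compound 4 has only carbon among its heavy atoms, so among these four compounds halogen on this ring is not needed to stay in this region of values. Nothing available explains why the values stay so close together.

As far as these compounds go, what remains open is whether any change at this position can move the number beyond the scatter. An amine or a carboxylic acid on this ring, or a chain longer than ethyl, would test that.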